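Vinyl to Ethyl on the Best Compound of a Small Series

The source may report more compounds than this note shows. Statements on the series, on what has been measured and on what is new or still open speak of the compounds shown alone.

Three compounds share one core and differ only in the group on one aromatic nitrogen. Compound 1 `C=CCn1c(=O)n(CCCCO)c2nc(N)nc(O)c21` carries an open chain there and in a functional assay on the whole organism with Mus musculus as the target (on this read-out higher numbers stand for larger maximal responses and lower numbers for smaller maximal responses), compound 1 gives 16%. Compound 2 `C=CCn1c(=O)n(C2C=CC(CO)O2)c2nc(N)nc(O)c21` carries a ring in that place, and in this assay compound 2 gives 84%, the highest of the three numbers; the change in this assay is a number 68 percentage points higher from compound 1 to compound 2 (beyond the scatter). Compound 3 `C=CCn1c(=O)n([C@H]2CO[C@@H](CO)C2)c2nc(N)nc(O)c21` carries a different ring there and in this assay compound 3 gives 16%; the step in this assay is a number 68 percentage points lower from compound 2 to compound 3 (beyond the scatter), while from compound 1 the step is no change at the digits printed from compound 1 to compound 3 (within the scatter).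

Compound 4 `CCCn1c(=O)n(C2C=CC(CO)O2)c2nc(N)nc(O)c21` keeps the ring of compound 2 and changes the other group: ethyl in place of vinyl on a saturated chain carbon bound to an aromatic nitrogen. Going by the values given here, none of the measured steps touches this group; all three vary the ring or chain on the aromatic nitrogen, so no measured step bears on the change from compound 2 to compound 4. The change swaps two small groups of equal size. Without a measured guide, the step in this assay is expected to be small, a number 6 percentage points lower from compound 2 to compound 4 (within the scatter), with wide uncertainty. Compound 4 is therefore estimated to give 78% in this assay, within a range from 45% to 95%.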

Compound 4, largest response reached (reported as maximal response), in percent of the reference or control that the assay uses: 84%
Estimate against measurement, compound 4: 6 percentage points below; the range from low to high includes it.
By their numbers in this assay, from the lowest: compounds 1 and 3 (each within the scatter of the next); then compounds 2 and 4 (each within the scatter of the next).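

In this assay, replacing vinyl with ethyl, which turns the allyl group into a propyl group, gives no change at the digits printed from compound 2 to compound 4 (within the scatter). Going by these compounds alone, the earlier steps all varied the ring or chain on the other aromatic nitrogen, so this is the first direct look at this position, and it shows that, with the ring of compound 2 in place, the large maximal response does not depend on the double bond of the allyl group. No separate measurement is available that would explain why the two groups read alike.

Allyl and propyl are the only groups shown at this position, so it remains open whether the response would hold with a longer chain such as pentyl, with a benzyl group, or with a chain ending in an amine. It is also open whether allyl and propyl would read alike alongside the open chain of compound 1 or the saturated ring of compound 3, since the pair shown here carries only the ring of compound 2.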